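The source may hold more compounds than are shown below. What is called first, only, known or untested is meant among the compounds shown, and "the series" means these compounds.

In a functional assay on HepG2 cells (Homo sapiens) for cytotoxicity, read by MTT assay, with a stated time of 72 h (on this read-out higher numbers stand for weaker inhibition and lower numbers for stronger inhibition), compound 1 `O=C(Nc1ccc(Oc2ccnc3[nH]ccc23)cc1)c1nn(-c2ccc(Cl)c(F)c2)ccc1=O` gives 5240 nM and compound 2 `O=C(Nc1ccc(Oc2ccnc3[nH]ccc23)c(F)c1)c1nn(-c2ccc(Cl)c(F)c2)ccc1=O` gives 9610 nM. Among the compounds with values here, compound 2 therefore stands within the scatter of compound 1, the only other measured member of the series. Compound 3 `Cn1ccc2c(Oc3ccc(NC(=O)c4nn(-c5ccc(Cl)c(F)c5)ccc4=O)cc3F)ccnc21` differs from compound 2 at one place: methyl in place of hydrogen on an aromatic nitrogen of a five-membered aromatic ring with 1 nitrogen.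

Within the data shown here, only one measured step is available, a 1.8-fold higher number from compound 1 to compound 2 (0.26 log units; within the scatter), for fluoro in place of hydrogen on an aromatic carbon. It is a different change at a different place, so it bears on the new step only indirectly, as one case of a single substitution that stayed within the scatter. Among the measured compounds shown here, no measured compound carries the methyl, and the data therefore give no direction for this change. No step beyond the scatter is expected in this assay, and the estimate corresponds to an expected 1.2-fold lower number from compound 2 to compound 3 (0.08 log units; within the scatter). Compound 3 is estimated at 8000 nM, with an expected range of 3000 nM to 20000 nM.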

Compound 3, half-maximal inhibitory concentration: 22100 nM
The estimate for compound 3 lay 2.8-fold (0.44 log units) below the measured number, outside the stated range (above it).
By their numbers in this assay, from the lowest: compounds 1 and 2 (each within the scatter of the next); then compound 3.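

In this assay methyl in place of hydrogen on an aromatic nitrogen of a five-membered aromatic ring with 1 nitrogen gives a 2.3-fold higher number from compound 2 to compound 3 (0.36 log units; beyond the scatter) and so moves the read-out towards weaker inhibition. Of the two single changes shown, this is the one that lies beyond the scatter, whereas fluoro in place of hydrogen on an aromatic carbon gives a 1.8-fold higher number from compound 1 to compound 2 (0.26 log units; within the scatter) and stays within it. This aromatic nitrogen is therefore a position where even one added carbon shifts the number in this assay, although the shift is modest and rests on a single pair, and no available evidence accounts for it.

The compounds shown carry only hydrogen or methyl on this nitrogen, so it remains open whether an ethyl group, a longer alkyl chain or a chain ending in an amine or a carboxylic acid would continue the shift, leave it unchanged or reverse it. Within the data shown here, it also remains open whether the methyl gives a similar step in the absence of the fluoro present in compound 2, since the only pair at this nitrogen carries that fluoro.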